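The source may report more compounds than this note shows. Statements on the series, on what has been measured and on what is new or still open speak of the compounds shown alone.

Compound 1 `CCOC(=O)C1CCCCN1S(=O)(=O)c1ccc(S(=O)(=O)N(CC)CC)cc1`: 24600 nM
Compound 2 `CCN(CC)S(=O)(=O)c1ccc(S(=O)(=O)N2CCC[C@@H](C(=O)N[C@H]3CCN(C(=O)OC(C)(C)C)C3)C2)cc1`: 100 nM
Compound 3 `CC(C)c1noc(N2CCN(C(=O)[C@@H]3CCCN(S(=O)(=O)c4ccc(S(=O)(=O)NC(C)(C)C)cc4)C3)CC2)n1`: 300 nM

Of the compounds shown here, three have been tested in a functional assay on MIA PaCa-2 cells (Homo sapiens) for inhibition, read by MTT assay, with a stated time of 7 days; a lower number here means a stronger inhibitor, a higher number a weaker inhibitor. Compound 1 gives 24600 nM, compound 2 gives 100 nM and compound 3 gives 300 nM. Among these three, compound 3 stands second highest: its gap to compound 2 is beyond the scatter, and its gap to compound 1 is far beyond it. The next compound to consider is compound 4 `CC(C)c1noc(N2CCN(C(=O)[C@@H]3CCCN(S(=O)(=O)c4ccc(S(=O)(=O)NC5CCC5)cc4)C3)CC2)n1`. It differs from compound 3 in one place only, (cyclobutyl in place of tert-butyl on a sulfonamide nitrogen). Both groups carry the same count of heavy atoms, and the exchange brings no change in hydrogen-bond donors, acceptors or charge; the only difference is that one group is a branched chain and the other a small ring. Nothing in the measured set shows how such a swap plays out in this assay, so no direction can be read from the data. The step from compound 3 to compound 4 is expected to be small, likely none beyond the scatter, in this assay, that is no change at the digits printed from compound 3 to compound 4 (within the scatter). Compound 4 is therefore estimated at 300 nM, with a range from 120 nM to 750 nM.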

Compound 4, half-maximal inhibitory concentration: 600 nM
For compound 4 the middle estimate is 2.0-fold (0.30 log units) below the measured one; the range from low to high includes it.
By their numbers in this assay, from the lowest: compound 2; then compounds 3 and 4 (each within the scatter of the next); then compound 1.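

In this assay, within the data shown here, putting cyclobutyl in place of tert-butyl on a sulfonamide nitrogen gives a 2.0-fold higher number from compound 3 to compound 4 (0.30 log units; within the scatter) and so offers the first direct comparison at this position, since the earlier compounds included no pair differing in one place. At this position, then, a small ring and a branched chain with the same count of heavy atoms cannot be told apart in this measurement, and the step shows no real gain or loss. Nothing available explains the result, so the comparison records only what was observed.

Both groups consist of carbon only, so the compounds shown leave open how this position responds to a hydroxyethyl chain, a carboxylic acid or an amine. They also leave open whether a phenyl ring or a larger ring such as cyclohexyl would fit the same picture.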